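The compounds below may be only part of what the source reports. "The series", "measured", "known", "first", "only" and "open" are said of these compounds alone.

Measured compounds:
- Compound 1, `Cc1cc2c(cc1C(=O)N=C(N)N)S(=O)(=O)CCC2`: 95 nM
- Compound 2, `Cc1cc2c(cc1C(=O)N=C(N)N)S(=O)(=O)CC2C(C)C`: 21 nM
- Compound 3, `Cc1cc2c(cc1C(=O)N=C(N)N)S(=O)(=O)C(C)C2N`: 56 nM

These three compounds share a core and were tested in an assay on cells for inhibition of sodium/hydrogen exchanger (Oryctolagus cuniculus); a lower number here means a stronger inhibitor, a higher number a weaker inhibitor. Compound 2 stands lowest of the three numbers and is therefore the strongest inhibitor in this assay: compound 3 gives a number beyond the scatter above it, and compound 1 gives a number further above still, also beyond the scatter. Compound 2 carries an isopropyl on the ring fused to the aromatic ring, while compound 3 carries an amino group and compound 1 carries no substituent there.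

Compound 4, `Cc1cc2c(cc1C(=O)N=C(N)N)S(=O)(=O)CC2O`, has not yet been measured. It differs from compound 2 by hydroxy in place of isopropyl on a saturated ring carbon. Going by the values given here, no measured pair shows this change directly, so the expectation rests on the spread seen among compounds 1, 2 and 3. Since compound 2 with its isopropyl gives 21 nM and the other two substitution patterns give higher numbers, the step of a 3.8-fold higher number from compound 2 to compound 4 (0.58 log units; beyond the scatter) is expected to move toward a weaker inhibitor, beyond the scatter. Compound 4 is estimated to give 80 nM in this assay, with a range from 25 nM to 250 nM.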

Compound 4, half-maximal inhibitory concentration: 70 nM
Beside the measured number, compound 4's estimate is 1.1-fold (0.06 log units) above it; the range from low to high includes it.
By their numbers in this assay, from the lowest: compound 2; then compounds 3, 4 and 1 (each within the scatter of the next).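

In this assay, exchanging isopropyl for hydroxy on this saturated ring carbon, two ring bonds from the ring sulfur, gives a 3.3-fold higher number from compound 2 to compound 4 (0.52 log units; beyond the scatter) and so a modest step beyond the scatter. Going by these compounds alone, this is the first direct reading at this position, since only the group changes on the same five-membered ring: compound 2 is the stronger inhibitor of the pair, while compound 4 still gives 70 nM in the same assay. Nothing measured here accounts for the rise in the number.

With a single exchange at this carbon, the compounds shown do not tell how a methyl, a longer chain or an amine would compare on the same five-membered ring. They also leave open whether a methoxy group, in place of hydroxy, would give a number closer to that of compound 2.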